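Whether removing a chloro group changes anything at the limit

The source may report more compounds than this note shows. Statements on the series, on what has been measured and on what is new or still open speak of the compounds shown alone.

Of the compounds shown here, three have so far been tested in a functional assay on MCF7 cells (Homo sapiens) for cytotoxicity, read by MTT assay, with a stated time of 72 h (on this read-out higher numbers stand for weaker inhibition and lower numbers for stronger inhibition), and none of them reaches a measurable value. Compound 1 `O=c1cc(CSc2nc3ccccc3s2)oc2ccccc12` returns only the assay limit, > 25000 nM. Compound 2 `O=c1cc(CSc2nc3ccccc3s2)oc2ccc(Cl)cc12`, which carries a chloro group, likewise stops at the limit, > 25000 nM. Compound 3 `Cc1nnc(SCc2cc(=O)c3cc(Cl)ccc3o2)o1`, built on a different core, also gives no more than the limit of > 25000 nM. How the core of compound 3 differs from that of compound 2 is not broken down here.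

Between compound 2 and compound 1 the single change is hydrogen in place of chloro on an aromatic carbon. The corresponding step, a step that the two limits leave unreadable from compound 2 to compound 1, cannot be sized because of the limit of > 25000 nM in this assay, at which 3 of the 3 values shown sit.

Compound 4 `Cc1nnc(SCc2cc(=O)c3ccccc3o2)o1` is the untested member of the set. It differs from compound 3 by hydrogen in place of chloro on an aromatic carbon, the same change as between compound 2 and compound 1, with the same surroundings of the place in both cases. Within these compounds the removal of the chloro group has therefore left no readable trace, and no pattern beyond them can be claimed.

The step expected from compound 3 to compound 4 in this assay is a step that the limit leaves unreadable from compound 3 to compound 4, resting on compound 2 and compound 1 both sitting at the limit (the limit of > 25000 nM in this assay, at which 3 of the 3 values shown sit). Compound 4 is accordingly expected to show 35000 nM, with an estimated range from 12000 nM to 100000 nM, and is most likely to return only a limit as well.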

Compound 4, half-maximal inhibitory concentration: > 25000 nM
Compound 4: no number, only a limit; the forecaster's own chance of this, stated with the estimate: 85%; the middle value lies beyond the limit too.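

In this assay, compound 3 and compound 4 both return only a limit, so no size can be read for the step between them, because neither gives a number: the limit of > 25000 nM in this assay, at which 4 of the 4 values shown sit.

The compounds shown leave open whether hydrogen in place of chloro on an aromatic carbon changes anything in this assay, and how these four compounds rank against one another.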